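Trading a chlorobenzyl amide for a methylated methoxybenzyl amide

This account rests on a few compounds, and the source may have more. Where it says the series, first, only, none or still open, it means among the compounds named here.

Measured compounds:
compound 1 `CCN(Cc1ccccc1)C(=O)c1nn(-c2ccc(F)cc2)c(OC[C@@H](O)C[C@@H](O)CC(=O)O)c1C(C)C`: 14 nM
compound 2 `COc1cccc(CNC(=O)c2nn(-c3ccc(F)cc3)c(OC[C@@H](O)C[C@@H](O)CC(=O)O)c2C(C)C)c1`: 16 nM
compound 3 `CC(C)c1c(C(=O)NCc2ccc(Cl)cc2)nn(-c2ccc(F)cc2)c1OC[C@@H](O)C[C@@H](O)CC(=O)O`: 6.7 nM

All three share one core and differ only in the amide group attached to a carbonyl carbon. In an assay on microsomes from liver for inhibition of 3-hydroxy-3-methylglutaryl-coenzyme A reductase (Rattus norvegicus) (on this read-out lower numbers stand for stronger inhibition and higher numbers for weaker inhibition), compound 3 gives the lowest number of the three, with compound 1 nearest at 14 nM and compound 2 furthest at 16 nM; both of these gaps lie beyond the scatter.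

Compound 4 `COc1cccc(CN(C)C(=O)c2nn(-c3ccc(F)cc3)c(OC[C@@H](O)C[C@@H](O)CC(=O)O)c2C(C)C)c1` differs from compound 3 in one place: (3-methoxybenzyl)(methyl)amino in place of (4-chlorobenzyl)amino on a carbonyl carbon. For the measured compounds named here, two measured steps bear on this. The step of a 2.4-fold lower number from compound 2 to compound 3 (0.38 log units; beyond the scatter) is the reverse of the aryl part of this change, so undoing it should raise the number by a modest amount. The step of a 1.1-fold higher number from compound 1 to compound 2 (0.06 log units; within the scatter) shows that swapping an alkylated benzyl amide for a methoxybenzyl amide made no difference beyond the scatter, so the added methyl on the nitrogen is not expected to shift the number much. Taken together, compound 4 is expected to show a 2.2-fold higher number from compound 3 to compound 4 (0.35 log units; beyond the scatter), a modest rise. The estimated value for compound 4 in this assay is 15 nM, with a range of 6 nM to 40 nM.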

Compound 4, half-maximal inhibitory concentration: 21 nM
The estimate for compound 4 lay 1.4-fold (0.15 log units) below the measured number, within the range that was stated.
By their numbers in this assay, from the lowest: compound 3; then compounds 1, 2 and 4 (each within the scatter of the next).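

Adding a methyl to the amide nitrogen of compound 2 gives a 1.3-fold higher number from compound 2 to compound 4 (0.12 log units; within the scatter) in this assay, so on this 3-methoxybenzyl amide, replacing the amide hydrogen with methyl produces no change beyond the scatter. Compound 4 also cannot be separated from compound 1, the other amide here without an amide hydrogen, with a 1.5-fold higher number from compound 1 to compound 4 (0.18 log units; within the scatter). The full exchange of the (4-chlorobenzyl)amino group for the (3-methoxybenzyl)(methyl)amino group does register, with a 3.1-fold higher number from compound 3 to compound 4 (0.50 log units; beyond the scatter), so the gap lies beyond the scatter even though the methyl step alone does not.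

No measurement shown explains these differences.
As far as these compounds go, it remains open whether the (4-chlorobenzyl)amino group would tolerate the same nitrogen methyl, and whether a longer propyl chain on the nitrogen of the 3-methoxybenzyl amide would leave the number unchanged.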